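Prop-1-en-1-yl in Place of Vinyl: Another Limit Expected

A few compounds are considered here, and "the series" means these few. Any claim that something is new, unique, unknown or untested is made for them only; others in the source may bear on it.

Compound 1 `C=CC(=O)Nc1ccc(Cn2nc(-c3ccc(Oc4ccccc4)cc3)cc2C(=O)O)cc1`: > 60000 nM
Compound 2 `C/C=C/C(=O)Nc1ccc(Cn2nc(-c3ccc(Oc4ccccc4)cc3)cc2C(=O)O)cc1`: > 60000 nM
Compound 3 `C=CC(=O)N1CCCC(n2nc(-c3ccc(Oc4ccccc4)cc3)cc2C(=O)O)C1`: > 60000 nM

In a functional assay on Maver1 cells (Homo sapiens) for inhibition, read by luminescence and CellTiter-Glo, with a stated time of 72 h (on this read-out lower numbers stand for stronger inhibition and higher numbers for weaker inhibition), compound 1 gives only a limit, > 60000 nM. Compound 2 likewise gives only a limit, > 60000 nM. Compound 3 too gives only a limit, > 60000 nM. The change from compound 1 to compound 2 is prop-1-en-1-yl in place of vinyl on a carbonyl carbon, and the step it made, a step that the two limits leave unreadable from compound 1 to compound 2, cannot be read because of the limit of > 60000 nM in this assay, at which 3 of the 3 values shown sit.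

Compound 4 `C/C=C/C(=O)N1CCCC(n2nc(-c3ccc(Oc4ccccc4)cc3)cc2C(=O)O)C1` has not been measured. Compound 3 and compound 1 share no single counted difference; how their cores differ is not broken down here. The change from compound 3 to compound 4 is prop-1-en-1-yl in place of vinyl on a carbonyl carbon; the place lines differ in that the carbonyl carbon of compound 3 neighbours an amide-type nitrogen in a ring, so this is the same kind of change as from compound 1 to compound 2, not the same one.

Given that compound 3 sits at the limit > 60000 nM, and that compound 1 and compound 2 both sit at the same limit, the step of a number no higher from compound 3 to compound 4 (the limit leaves the size open) is expected to leave compound 4 unreadable as well. Compound 4 is therefore estimated at 60000 nM in this assay, most likely reported only as a limit.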

Compound 4, half-maximal inhibitory concentration: > 60000 nM
Compound 4: a limit, no number (the forecaster's own chance of this, stated with the estimate: 85%); the middle value lies on the limit itself.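

Compound 4 gives > 60000 nM in this assay, which is a limit and not a number. The step from compound 3 to compound 4 therefore cannot be read, because both compounds stop at the same limit: the limit of > 60000 nM in this assay, at which 4 of the 4 values shown sit. The compounds shown leave open how prop-1-en-1-yl compares with vinyl in this assay, and how the four compounds compare with one another.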